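A Triazolylmethyl Replacement and Its Expected Liver Microsome Stability

The compounds below may be only part of what the source reports. "The series", "measured", "known", "first", "only" and "open" are said of these compounds alone.

This account follows a single change in a series of compounds that share one core, measured in an ADME assay on microsomes from liver (Rattus norvegicus) for metabolic stability; on this read-out lower numbers stand for a shorter-lived compound and higher numbers for a longer-lived compound. Compound 1, `CCn1ncc2c(F)cc(-c3ccc(C(CC)(CC)c4nnc(C)[nH]4)c(=O)[nH]3)cc21`, reaches the limit of the assay in this assay at > 3 h; that is a limit and not a number. Compound 3, `CCC(CC)(c1nnc[nH]1)c1ccc(-c2ccc3cc(F)cc(F)c3c2)[nH]c1=O`, gives 1.26 h in this assay. Compound 2, `CC(C)C(c1ccc(-c2ccc3cccc(F)c3c2)[nH]c1=O)N1CCN/C1=N\C#N`, gives 0.327 h in this assay, the lowest of the two numbers in this set, with compound 3 at the nearest value and that gap lying beyond the scatter.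

The new compound, compound 4, `CC(C)C(Cc1nnc[nH]1)c1ccc(-c2ccc3cccc(F)c3c2)[nH]c1=O`, differs from compound 2 in one place: a group of 6 heavy atoms (3 carbon, 3 nitrogen; one five-membered aromatic ring with 3 hetero atoms) in place of a group of 8 heavy atoms (4 carbon, 4 nitrogen; one five-membered non-aromatic ring with 2 hetero atoms), on a saturated chain carbon bound to an aromatic carbon and a saturated chain carbon. Among the measured compounds shown here, no step between measured compounds reproduces this exchange, so the expectation rests on the values shown. The triazole of compound 4 brings it nearer to compound 3, and because compound 3 gives 1.26 h in this assay, the step from compound 2 to compound 4 is expected to be upward, by a 2.1-fold higher number from compound 2 to compound 4 (0.33 log units; beyond the scatter), clearly beyond the scatter. Compound 4 is therefore estimated to give 0.7 h in this assay, in a range from 0.3 h to 1.8 h.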

Compound 4, half-life: 0.1 h
Compound 4: middle estimate off by 7.0-fold (0.85 log units), on the high side; the measured number lies below the stated range.
By their numbers in this assay, from the lowest: compound 4; then compound 2; then compound 3. At a limit, above all of these: compound 1.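

Among the compounds shown here, this is the first step in the set that can be read at this position: in this assay, putting (4H-1,2,4-triazol-3-yl)methyl in place of the group with the five-membered non-aromatic ring, on a saturated chain carbon bound to an aromatic carbon and a saturated chain carbon, gives a 3.3-fold lower number from compound 2 to compound 4 (0.51 log units; beyond the scatter) and so a shorter-lived compound. The earlier compounds shown here could not show the direction of this change, as no two of them differ in only one place. Compound 3 also carries a triazole ring, but it differs from compound 4 in more than one place, so its value cannot be carried over to this position.

Nothing shown here accounts for the shorter half-life of compound 4. As far as these compounds go, it remains open how an amine or a carboxylic acid on the same saturated chain carbon would compare with these two groups, and whether the same exchange would move the number in the same direction on the rest of compound 3 or compound 1.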